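Naphthalen-1-yl for 4-formylphenyl on the benzyl core

The source may hold more compounds than are shown below. What is called first, only, known or untested is meant among the compounds shown, and "the series" means these compounds.

Measured so far in a functional assay on RPMI-8226 cells (Homo sapiens) for inhibition, read by sulforhodamine B assay, with a stated time of 48 h, tested at 10 uM; a lower number here means less inhibition, a higher number more inhibition at the concentration tested (going by the name of the read-out):
compound 1 `O=Cc1ccc(-c2cn3ccnc3c(-c3ccc4ncn(C5CCCCC5)c4c3)n2)cc1` gives 82.5%
compound 2 `c1ccc2c(-c3cn4ccnc4c(-c4ccc5ncn(C6CCCCC6)c5c4)n3)cccc2c1` gives 22.9%
compound 3 `O=Cc1ccc(-c2cn3ccnc3c(-c3ccc4ncn(Cc5ccccc5)c4c3)n2)cc1` gives 82.5%

Compound 4 `c1ccc(Cn2cnc3ccc(-c4nc(-c5cccc6ccccc56)cn5ccnc45)cc32)cc1` is not yet measured in this assay. The two cores differ as described by benzyl in place of cyclohexyl on an aromatic nitrogen; that change made no change at the digits printed from compound 1 to compound 3 (within the scatter). The change from compound 3 to compound 4 is naphthalen-1-yl in place of 4-formylphenyl on an aromatic carbon. The same change, (naphthalen-1-yl in place of 4-formylphenyl on an aromatic carbon), has been measured once, where it made a number 59.6 percentage points lower from compound 1 to compound 2 (beyond the scatter). Within the data shown here, both place lines read the same word for word, so this is the same change, though only one pair so far shows its effect. Since compound 3 stands level with compound 1, compound 4 is expected to fall by about the same amount, a number 58.5 percentage points lower from compound 3 to compound 4 (beyond the scatter), because of a number 59.6 percentage points lower from compound 1 to compound 2 (beyond the scatter). On that basis compound 4 is estimated at 24% in this assay, with a likely range from 8% to 42%.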

Compound 4, a percentage reported as inhibition, at one concentration (the size of the read-out at that concentration, not a potency): 26.9%
Estimate against measurement, compound 4: 2.9 percentage points below, within the range that was stated.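

In this assay, naphthalen-1-yl in place of 4-formylphenyl gives a large step on the benzyl core as well, a number 55.6 percentage points lower from compound 3 to compound 4 (beyond the scatter), and the two cores agree on its size: the same change on two cores in this assay, a number 59.6 percentage points lower (beyond the scatter) from compound 1 to compound 2 and a number 55.6 percentage points lower (beyond the scatter) from compound 3 to compound 4, 4 percentage points apart, within the scatter of two such steps. Benzyl in place of cyclohexyl stays within the scatter when naphthalen-1-yl is present, a number 4 percentage points higher from compound 2 to compound 4 (within the scatter), and that result also holds across both pairs: the same change on two cores in this assay, no change at the digits printed (within the scatter) from compound 1 to compound 3 and a number 4 percentage points higher (within the scatter) from compound 2 to compound 4, 4 percentage points apart, within the scatter of two such steps. The two changes therefore read as independent in these four compounds, but this rests on two nitrogen substituents and two aryl groups at one concentration and does not show why the value falls.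

Open, as far as these compounds go, is what a carboxylic acid or an amine in place of the formyl group would give. Also open, from the compounds shown here alone, is whether the changes stay independent with a longer chain on the aromatic nitrogen.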